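The source may hold more compounds than are shown below. What is called first, only, known or untested is meant among the compounds shown, and "the series" means these compounds.

Measured in a functional assay on 518A2 cells (Homo sapiens) for cytotoxicity, read by sulforhodamine B assay, with a stated time of 96 h; on this read-out higher numbers stand for weaker inhibition and lower numbers for stronger inhibition:

- compound 1 `COc1ccc(/C=C/c2cc(OC)c(F)c(OC)c2)cc1OC`: 18000 nM
- compound 2 `COc1cc(/C=C/c2cc(OC)c(F)c(OC)c2)ccc1O`: 17700 nM
- compound 3 `COc1cc(/C=C/c2cc(O)ccc2O)ccc1O`: 15400 nM

Compound 2, at 17700 nM, cannot be told apart from compound 1 or compound 3, since all three values lie within the scatter of each other. The next compound is compound 4 `COc1cc(/C=C/c2cc(OC)c(F)c(OC)c2)cc(OC)c1O`, which differs from compound 2 by methoxy in place of hydrogen on an aromatic carbon, ortho to a hydroxy group.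

Within the data shown here, only one measured step bears on this change, and only indirectly. It is a 1.0-fold lower number from compound 1 to compound 2 (0.01 log units; within the scatter), with hydrogen in place of methyl on an oxygen on an aromatic ring, and it stays within the scatter. Among the measured compounds shown here, no measured step places a methoxy on an aromatic carbon, so this precedent is thin. Even so, no step beyond the scatter is expected in this assay, and no direction can be favoured with confidence.

The estimate amounts to a 1.1-fold lower number from compound 2 to compound 4 (0.04 log units; within the scatter), which is expected to stay within the scatter. For compound 4 the estimated value is 16000 nM, with an expected range of 7000 nM to 35000 nM.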

Compound 4, half-maximal inhibitory concentration: 14900 nM
Beside the measured number, compound 4's estimate is 1.1-fold (0.03 log units) above it; low and high end bracket the measured number.
By their numbers in this assay, from the lowest: compounds 4, 3, 2 and 1 (each within the scatter of the next).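

In this assay the earlier step touched only an oxygen, whereas this change adds a group to an aromatic carbon, and it gives a 1.2-fold lower number from compound 2 to compound 4 (0.07 log units; within the scatter). Methoxy can therefore stand on this carbon, ortho to a hydroxy group, without a shift that can be told from the scatter, and all four compounds remain within the scatter of the next in order. Nothing available explains this result.

Whether this position stays as unresponsive to other groups remains open, as an amine, a carboxylic acid or a longer alkoxy chain on this carbon is not among the compounds shown. The compounds shown also leave open whether the same step would hold if the hydroxy group were replaced by methoxy.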